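This account rests on a few compounds, and the source may have more. Where it says the series, first, only, none or still open, it means among the compounds named here.

Measured so far:
- compound 1, `CC1(C)Oc2ccc(C#N)c(N3CCCC3=O)c2C[C@@H]1O`: 32000 nM
- compound 2, `CC1(C)CC(NC(=O)Nc2ccccc2)c2cc(C#N)ccc21`: 1300000 nM
- compound 3, `CC(C)(C)c1ccc(C#N)cc1NC(=O)Nc1ccccc1`: 1700000 nM

In a functional assay (aorta) for inhibition, with Rattus norvegicus as the target (a lower number here means a stronger inhibitor, a higher number a weaker inhibitor), compound 3 gives 1700000 nM, the highest of the three numbers. Its gap to compound 2 is within the scatter, so the two cannot be ordered; its gap to compound 1 is far beyond the scatter, compound 1 giving 32000 nM in this assay and standing as the strongest inhibitor of the set. Within the data shown here, no pair of measured compounds differs in one place, so no single step within the set can be read off.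

Compound 4, `CC(C)(C)c1ccc(C#N)cc1NC(=O)Nc1ccccn1`, differs from compound 3 in one place: pyridin-2-yl in place of phenyl on an amide-type nitrogen. Among the measured compounds shown here, no measured pair shows what such a change does here. The urea-bearing compounds 2 and 3 both lie at very high numbers in this assay, and the change keeps the whole urea arrangement and the rest of compound 3 intact. The expectation is therefore a step from compound 3 to compound 4 of a 1.1-fold lower number from compound 3 to compound 4 (0.05 log units; within the scatter), that is, no change beyond the scatter in either direction. For compound 4 the estimate in this assay is 1500000 nM, with a range from 400000 nM to 5000000 nM.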

Compound 4, half-maximal inhibitory concentration: 25700000 nM
The estimate for compound 4 lay 17-fold (1.23 log units) below the measured number; the whole stated range lies below it.
By their numbers in this assay, from the lowest: compound 1; then compounds 2 and 3 (each within the scatter of the next); then compound 4.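

In this assay, pyridin-2-yl in place of phenyl on an amide-type nitrogen gives a 15-fold higher number from compound 3 to compound 4 (1.18 log units; beyond the scatter) and so a weaker inhibitor. This position is therefore sensitive to the ring it carries, even with the urea and the rest of compound 3 unchanged, and exchanging one ring carbon for nitrogen is enough to produce a step beyond the scatter. No supporting measurement is available to explain the step.

A single pair cannot show whether the loss belongs to the ring nitrogen itself or to pyridin-2-yl alone. Also open, going by these compounds, is how this position would respond to a pyrimidinyl group, or to a phenyl ring carrying an amine or a carboxylic acid, and whether the same change would have a similar effect on the core of compound 2.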